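The source may report more compounds than this note shows. Statements on the series, on what has been measured and on what is new or still open speak of the compounds shown alone.

Compound 1, `CCOC(=O)CCCCCOc1cccc(CN(C(=O)c2ccc(-c3cccc(C(C)=O)c3)cc2)C(C)C)c1`: in an ADME assay on HepG2 cells (Homo sapiens) for cytotoxicity, read by CellTiter-Glo and resazurin assay, with a stated time of 72 h (on this read-out higher numbers stand for an effect only at larger amounts of compound and lower numbers for an effect already at smaller amounts), compound 1 gives > 26000 nM, which is a limit of the assay and not a number.
Compound 2, `CCOC(=O)CCCCCOc1cccc(CNC(C)C)c1`: in this assay compound 2 gives > 26000 nM, also a limit.
Compound 3, `CCCNCc1cccc(OCCCCCC(=O)OCC)c1`: in this assay compound 3 gives > 26000 nM, again a limit.

All three values sit at the limit of > 26000 nM in this assay, at which 3 of the 3 values shown sit. Compound 3 therefore stands exactly where compounds 1 and 2 stand: at the edge of what this assay reports, with no number of its own. For the measured compounds named here, the single measured step that touches this part of the series, a step that the two limits leave unreadable from compound 2 to compound 3, cannot be read in size; both of its ends are limits.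

Compound 4, `CCOC(=O)CCCCCOc1cccc(C=O)c1`, has not yet been measured. The change from compound 3 is formyl in place of (propylamino)methyl on an aromatic carbon. Going by the values given here, no measured step gives a size for such a change; the expectation rests only on the three limits. The expected step, a step that the limit leaves unreadable from compound 3 to compound 4, is none beyond the scatter. Compound 4 is expected to give 30000 nM in this assay, with a range from 10000 nM to 100000 nM, and most probably the assay will again report a limit rather than a number.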

Compound 4, half-maximal effective concentration: > 26000 nM
Compound 4: no number, only a limit; the forecaster's own chance of this, stated with the estimate: 75%; the middle value is on the limit's open side.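

Compound 4 also ends at a limit and not a number, so no size can be read for its steps from compound 2 or from compound 3, whose results are limits too: the limit of > 26000 nM in this assay, at which 4 of the 4 values shown sit.

The compounds shown leave open at what concentration, if any, each of them would produce an effect in this assay.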